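Vero Cell Cytotoxicity Across Three Measured Analogues And A Fourth

The source may hold more compounds than are shown below. What is called first, only, known or untested is meant among the compounds shown, and "the series" means these compounds.

Compound 1 `CCOC(=O)c1cc(-c2cccc(OCc3cccc(F)c3)c2)on1` was examined in an ADME assay on Vero cells (Chlorocebus sabaeus) for cytotoxicity, with a stated time of 72 h; on this read-out higher numbers stand for weaker inhibition and lower numbers for stronger inhibition. Compound 1 returns only a limit there, > 128000 nM. Compound 2 `CCOC(=O)c1cc(-c2cccc(OCc3cccc(N)c3)c2)on1` carries an amino group in place of the fluoro group; in this assay compound 2 likewise returns only a limit, > 128000 nM. Compound 3 `CCOC(=O)c1cc(-c2cccc(OCc3cc(F)ccc3F)c2)on1` stands at a limit as well, giving > 128000 nM in this assay. Because all three values sit at the same limit (the limit of > 128000 nM in this assay, at which 3 of the 3 values shown sit), the steps a step that the two limits leave unreadable from compound 1 to compound 2, a step that the two limits leave unreadable from compound 1 to compound 3 and a step that the two limits leave unreadable from compound 2 to compound 3 cannot be read, and none of them yields a size in either direction. Compound 4 `CCOC(=O)c1cc(-c2cccc(OCc3ccc(F)c(F)c3F)c2)on1` differs from compound 3 by 2,3,4-trifluorophenyl in place of 2,5-difluorophenyl on a saturated chain carbon bound to an oxygen on an aromatic ring. For the measured compounds named here, the measured steps that bear on this change are the two that involve compound 3, yet both are unreadable, so no sized step can be expected in this assay, only that compound 4 will most probably sit at the limit too. Compound 4 is therefore expected to give about 150000 nM in this assay, within 60000 nM to 400000 nM. This estimate corresponds to an expected step that the limit leaves unreadable from compound 3 to compound 4.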

Compound 4, half-maximal inhibitory concentration: > 128000 nM
Compound 4: only a limit was reported; the forecaster's own chance of this, stated with the estimate: 85%; the middle value does not contradict the limit.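

Compound 4 returns only a limit in this assay, so no step between it and compound 1, compound 2 or compound 3 can be read: the limit of > 128000 nM in this assay, at which 4 of the 4 values shown sit.

The compounds shown leave open whether any of these four truly differs from another in this assay.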